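This account rests on a few compounds, and the source may have more. Where it says the series, first, only, none or still open, it means among the compounds named here.

In a functional assay on the whole organism (strain albino) for inhibition, with Rattus norvegicus as the target, read by paw edema, with stated times of 30 min and 2 h, at a dose of 0.28 mmol/kg by the oral route (a lower number here means less inhibition, a higher number more inhibition at the dose given (going by the name of the read-out)), compound 1 `COc1cc(-c2nnc(SCC(=O)Nc3ccc(/C(C)=N/O)cc3)n2-c2ccccc2)cc(OC)c1OC` gives 62%. Compound 3 `COc1ccc(-c2nnc(SCC(=O)Nc3ccc(/C(C)=N/O)cc3)n2-c2ccccc2)cc1OC` gives 63% and compound 2 `COc1ccc(-c2nnc(SCC(=O)Nc3ccc(/C(C)=N/O)cc3)n2-c2ccccc2)cc1` gives 56%, so compound 1 stands within the scatter of both: a number 1 percentage points higher from compound 1 to compound 3 (within the scatter), a number 6 percentage points lower from compound 1 to compound 2 (within the scatter) and a number 7 percentage points higher from compound 2 to compound 3 (within the scatter) are all small. Compound 4 `COc1cc(-c2nnc(SCC(=O)Nc3ccc(C(C)=O)cc3)n2-c2ccccc2)cc(OC)c1OC` differs from compound 1 in one place: a group of 3 heavy atoms (2 carbon, 1 oxygen; no ring) in place of a group of 4 heavy atoms (2 carbon, 1 nitrogen, 1 oxygen; no ring), on an aromatic carbon. Among the measured compounds shown here, none of the measured steps bears on this change; all three exchange methoxy for hydrogen or a 4-methoxyphenyl for a 3,4,5-trimethoxyphenyl, and leave the replaced group untouched. The data therefore give no ground for expecting a step in this assay beyond the scatter in either direction. Compound 4 is expected to give 60% in this assay, within 45% to 74%. The expected step is a number 2 percentage points lower from compound 1 to compound 4 (within the scatter).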

Compound 4, a percentage reported as inhibition, in the whole organism at one dose (the size of the read-out at that dose, not a potency): 54%
Beside the measured number, compound 4's estimate is 6 percentage points above it; measured number inside the range.
By their numbers in this assay, from the lowest: compounds 4, 2, 1 and 3 (each within the scatter of the next).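

Replacing the group of 4 heavy atoms with acetyl, on an aromatic carbon para to a large group, gives a number 8 percentage points lower from compound 1 to compound 4 (within the scatter) in this assay. This is the only step shown at this position, and with 1 hydrogen-bond donor leaving and 0 hydrogen-bond donors entering, the read-out does not move beyond the scatter. No measurement here accounts for this step.

From the compounds shown here alone, whether an amine or a carboxylic acid at this position would also stay within the scatter remains open. So does whether acetyl would give a similar step in compound 2 or compound 3.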